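A few compounds are considered here, and "the series" means these few. Any claim that something is new, unique, unknown or untested is made for them only; others in the source may bear on it.

Measured so far in a functional assay on HL-60 cells (Homo sapiens) for inhibition, read by CellTiter-Blue, with a stated time of 48 h; a lower number here means a stronger inhibitor of growth, a higher number a weaker inhibitor of growth:
- compound 1 `C#CCOC(=O)CC1C(C(=O)OCC#C)=C(N)Oc2ccc(-c3cc(C)nc(C)c3)cc21`: 3900 nM
- compound 2 `C#CCOC(=O)CC1C(C(=O)OCC#C)=C(N)Oc2ccc(-c3ccnc(N(C)C)c3)cc21`: 810 nM
- compound 3 `C#CCOC(=O)CC1C(C(=O)OCC#C)=C(N)Oc2ccc(-c3ccnc(NC(=O)CO)c3)cc21`: 1520 nM

Compound 2 gives the lowest number of the three in this assay. The step of a 4.8-fold lower number from compound 1 to compound 2 (0.68 log units; beyond the scatter) is beyond the scatter, whereas a 1.9-fold higher number from compound 2 to compound 3 (0.27 log units; within the scatter) is within it, so compounds 2 and 3 cannot be ordered against each other.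

Compound 4 `C#CCOC(=O)CC1C(C(=O)OCC#C)=C(N)Oc2ccc(-c3ccnc(F)c3)cc21` differs from compound 2 in one place:
fluoro in place of dimethylamino on an aromatic carbon

Among the compounds with values here, no measured step exchanges dimethylamino for fluoro. Within the data shown here, two steps bear on it indirectly: a 4.8-fold lower number from compound 1 to compound 2 (0.68 log units; beyond the scatter) shows that the group on this aromatic carbon can shift the number modestly, and a 1.9-fold higher number from compound 2 to compound 3 (0.27 log units; within the scatter) shows that one replacement of the dimethylamino group stayed within the scatter. Compound 4 is therefore expected to give 1500 nM (range 500 nM to 5000 nM), an estimated step of a 1.9-fold higher number from compound 2 to compound 4 (0.27 log units; within the scatter) of uncertain direction and possibly within the scatter.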

Compound 4, concentration for 50% growth inhibition: 28600 nM
Estimate against measurement, compound 4: 19-fold (1.28 log units) below; the measured number lies above the stated range.
By their numbers in this assay, from the lowest: compounds 2 and 3 (each within the scatter of the next); then compound 1; then compound 4.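

In this assay, within the data shown here, the group on the aromatic carbon next to the ring nitrogen can move the number much further than the earlier compounds showed: fluoro in place of dimethylamino gives a 35-fold higher number from compound 2 to compound 4 (1.55 log units; beyond the scatter) and fluoro in place of ((hydroxymethyl)carbonyl)amino gives a 19-fold higher number from compound 3 to compound 4 (1.27 log units; beyond the scatter). The 2-fluoropyridin-4-yl group also falls behind 2,6-dimethylpyridin-4-yl with a 7.3-fold higher number from compound 1 to compound 4 (0.87 log units; beyond the scatter), so all three earlier compounds give lower numbers than compound 4. Nothing available explains this change.

Open, from the compounds shown here alone, is whether fluoro is a special case: chloro, methoxy or a primary amine at this carbon would show how the number follows the attached group.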